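The compounds below may be only part of what the source reports. "The series", "measured", "known", "first", "only" and "open" are said of these compounds alone.

Compound 1: `O=C1c2c[n+]([O-])c3ccccc3c2C(=O)c2c1c1ccccc1n2CCCCN1CCNCC1` gives 3310 nM in a functional assay on MDA-MB-231 cells (Homo sapiens) for cytotoxicity, read by MTT assay, with a stated time of 72 h; on this read-out higher numbers stand for weaker inhibition and lower numbers for stronger inhibition.
Compound 2: `CN(C)CCCCn1c2c(c3ccccc31)C(=O)c1c[n+]([O-])c3ccccc3c1C2=O` gives 350 nM.

Within the data shown here, compound 2 stands lowest of the two measured numbers, the single step being a 9.5-fold lower number from compound 1 to compound 2 (0.98 log units; beyond the scatter). Compound 3, `CN1CCN(CCCn2c3c(c4ccccc42)C(=O)c2c[n+]([O-])c4ccccc4c2C3=O)CC1`, differs from compound 2 by 4-methylpiperazin-1-yl in place of (dimethylamino)methyl on a saturated chain carbon, three bonds along the chain from an aromatic nitrogen. Among the measured compounds shown here, only the step from compound 1 bears on this, and it moved the number in the opposite direction when the ring left. The ring now returns, though methylated and on a shorter chain, so a rise is expected, estimated as a 3.4-fold higher number from compound 2 to compound 3 (0.54 log units; beyond the scatter). Compound 3 is therefore expected near 1200 nM, within 400 nM to 3500 nM.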

Compound 3, half-maximal inhibitory concentration: 390 nM
Estimate against measurement, compound 3: 3.1-fold (0.49 log units) above; measured number below the stated range.
By their numbers in this assay, from the lowest: compounds 2 and 3 (each within the scatter of the next); then compound 1.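

In this assay, the ring alone does not set compound 1 apart: with a 1.1-fold higher number from compound 2 to compound 3 (0.05 log units; within the scatter), 4-methylpiperazin-1-yl stands in for (dimethylamino)methyl and the number stays within the scatter. Yet an 8.5-fold lower number from compound 1 to compound 3 (0.93 log units; beyond the scatter) lies beyond the scatter, and this step changes both the methyl on the ring and the chain length, so neither change can be credited alone. No evidence is at hand to explain these numbers.

Open, from the compounds shown here alone, is how piperazin-1-yl would read on the chain of compound 3, and 4-methylpiperazin-1-yl on the chain of compound 1. Also open, going by these compounds, is how a morpholine or a primary amine would read at the chain end.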